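Replacing the 2-Fluorophenyl of Compound 1 with Cyclohexyl

This account rests on a few compounds, and the source may have more. Where it says the series, first, only, none or still open, it means among the compounds named here.

The series is built on a shared core, seen in compound 1 `Cc1cc(C(=O)O)ccc1CN1CCC[C@H](O[C@H](CO)c2cc(Cl)cc(Cl)c2)[C@@H]1c1ccccc1F`, which carries a 2-fluorophenyl group on a saturated ring carbon. Compound 1 was run in an assay on isolated protein for activation of cGMP-dependent protein kinase 1 (Homo sapiens), read by ADP-Glo, with stated times of 30 min and 2 h (a lower number here means that less compound is needed, a higher number that more compound is needed for the effect), where compound 1 is recorded as "nd" (no result reported), so it stands without a value of its own. Two relatives give a sense of where the series sits. Compound 2 `Cc1cc(C(=O)O)ccc1CN1CC[C@H](OC(CO)c2cc(Cl)cc(Cl)c2)[C@@H]1c1ccccc1`, whose core ring is five-membered, gives 185000 nM in this assay. Compound 3 `Cc1cc(C(=O)O)ccc1CN1CCC[C@H](O[C@H](CF)c2cc(Cl)cc(Cl)c2)[C@@H]1c1ccccc1`, which keeps the six-membered ring and carries a fluoromethyl chain instead of the hydroxymethyl, gives 20000 nM in this assay.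

Compound 4 `Cc1cc(C(=O)O)ccc1CN1CCC[C@H](O[C@H](CO)c2cc(Cl)cc(Cl)c2)[C@@H]1C1CCCCC1` differs from compound 1 in one place: cyclohexyl in place of 2-fluorophenyl on a saturated ring carbon. Since compound 1 has no number, no step size can be stated for this change in this assay, and its direction is open. Compound 4 is expected to give roughly 50000 nM in this assay, with a range from 10000 nM to 250000 nM, an estimate resting only on the values of compound 2 and compound 3.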

Compound 4, half-maximal effective concentration: > 200000 nM
Compound 4 was reported as a limit (the forecaster's own chance of this, stated with the estimate: 25%); middle value at least 4.0-fold (0.60 log units) away from the limit.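

No step can be read between compound 1 and compound 4, as compound 1 has no reported result. In this assay compound 4 gives > 200000 nM, which is a limit and not a number. As far as these compounds go, how cyclohexyl compares with 2-fluorophenyl at this saturated ring carbon remains open.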